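The compounds below may be only part of what the source reports. "The series", "measured", "known", "first", "only" and "open" are said of these compounds alone.

Working notes on the series. Compound 1 `Clc1ccc(Nc2nc3c(N4CCCC4)ncnc3s2)cc1` is the point of reference. In a functional assay on CHO-K1 cells for antagonist activity at adenosine receptor A2b (Homo sapiens), read by 33P incorporation, with a stated time of 20 min, in the presence of a further agent that is not named here (a higher number here means a weaker inhibitor, a lower number a stronger inhibitor), compound 1 returns > 10000 nM, which is a limit of the measurement and not a number. Compound 2 `Fc1cccc(F)c1Nc1nc2c(Cl)ncnc2s1` returns > 10000 nM in this assay, again only a limit. Compound 3 `Clc1ncnc2sc(Nc3ccccc3)nc12` returns > 10000 nM in this assay, also a limit. On the numbers shown compound 1 therefore stands at the limit together with the other two, and nothing separates the three because of the limit of > 10000 nM in this assay, at which 3 of the 3 values shown sit.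

Within the data shown here, no two measured compounds differ in a single place, so no measured step is available to weigh the change toward compound 4 `CN(C)c1ncnc2sc(Nc3ccc(Cl)cc3)nc12`. The change from compound 1 is dimethylamino in place of pyrrolidin-1-yl on an aromatic carbon. The pyrrolidin-1-yl ring on the core of compound 1 gives way to a dimethylamino group at the same aromatic carbon.

With every measured value sitting at the limit, the expected step in this assay is none beyond the scatter, in either direction. Compound 4 is expected to give 15000 nM in this assay, within a range of 5000 nM to 50000 nM. The step this implies, a step that the limit leaves unreadable from compound 1 to compound 4, is expected to stay within the scatter, and a limit rather than a number is the likely report.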

Compound 4, inhibition constant: > 10000 nM
Compound 4 ended at the assay's limit (the forecaster's own chance of this, stated with the estimate: 80%); the middle value is on the limit's open side.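

In this assay compound 4 gives > 10000 nM as a limit and not a number. Among these compounds, no step from compound 1 to compound 4 can be read, because both values are limits: (the limit of > 10000 nM in this assay, at which 4 of the 4 values shown sit). The compounds shown leave open whether any change on the shared core gives a readable value in this assay at all.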